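A methylsulfonyl for a methyl in a cytotoxicity series

The source may report more compounds than this note shows. Statements on the series, on what has been measured and on what is new or still open speak of the compounds shown alone.

Compound 2 `Cc1ccc(-c2csc(N3N=C(c4ccc(Cl)s4)CC3c3ccc(F)cc3)n2)cc1` was tested in an ADME assay on NIH3T3 cells (Mus musculus) for cytotoxicity, read by XTT assay, with a stated time of 24 h; a lower number here means a stronger inhibitor, a higher number a weaker inhibitor. In that assay compound 2 reports only the limit of the measurement, > 500 ug/mL, so no number is known for it. Compound 1 `Fc1ccc(C2CC(c3ccc(Cl)s3)=NN2c2nc(-c3ccc(Cl)cc3)cs2)cc1` is its nearest neighbour among the measured compounds. In this assay compound 1 likewise reports the limit > 500 ug/mL. The change methyl in place of chloro on an aromatic carbon gives a step that the two limits leave unreadable from compound 1 to compound 2, and the two limits leave that step unreadable. Among the compounds with values here, the only evidence from the measured pair is therefore (the limit of > 500 ug/mL in this assay, at which 2 of the 2 values shown sit).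

Compound 3 `CS(=O)(=O)c1ccc(-c2csc(N3N=C(c4ccc(Cl)s4)CC3c3ccc(F)cc3)n2)cc1` is the next member of the series. The change from compound 2 is methylsulfonyl in place of methyl on an aromatic carbon. Within the data shown here, no measured step bears on this change, since the single step between measured compounds cannot be read. Both measured compounds sit at the limit, and the expectation for compound 3 rests on that alone. For the step of a number no higher from compound 2 to compound 3 (the limit leaves the size open) no change beyond the scatter is expected. Compound 3 is estimated at 500 ug/mL, with a range from 200 ug/mL to 1500 ug/mL.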

Compound 3, half-maximal inhibitory concentration: > 500 ug/mL
Compound 3: no number, only a limit; the forecaster's own chance of this, stated with the estimate: 80%; the middle value lies on the limit itself.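

In this assay compound 3 gives > 500 ug/mL, which is a limit and not a number. No step among compound 1, compound 2 and compound 3 can be read, because all three stop at the same limit: the limit of > 500 ug/mL in this assay, at which 3 of the 3 values shown sit.

The compounds shown leave open whether chloro, methyl or methylsulfonyl on that aromatic carbon makes any difference to the read-out.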